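Cycloheptyl to cyclopentyl on the amide

The compounds below may be only part of what the source reports. "The series", "measured", "known", "first", "only" and "open" are said of these compounds alone.

In a physicochemical assay for lipophilicity (on this read-out higher numbers stand for higher lipophilicity and lower numbers for lower lipophilicity), compound 1 `CC(C)=CCC/C(C)=C/CC/C(C)=C/CSC[C@H](NC(=O)CCCCCN1CCN(C)CC1)C(=O)NC1CCCCCC1` stands highest of the three measured compounds at 5.44, ahead of compound 3 `CC(C)=CCC/C(C)=C/CC/C(C)=C/CSC[C@H](NC(=O)CCCCCN1CCN(C)CC1)C(=O)N1CCCCC1` at 4.27 and compound 2 `CC(C)=CCC/C(C)=C/CC/C(C)=C/CSC[C@H](NC(=O)CCCCCN1CCCC1)C(=O)NC1CCCC1` at 4.04. Compound 4 `CC(C)=CCC/C(C)=C/CC/C(C)=C/CSC[C@H](NC(=O)CCCCCN1CCN(C)CC1)C(=O)NC1CCCC1` carries cyclopentyl in place of cycloheptyl on an amide-type nitrogen. For the measured compounds named here, the one measured step that touches this amide is a number 1.17 log units lower from compound 1 to compound 3 (beyond the scatter), with piperidin-1-yl in place of cycloheptylamino. Compound 2 also has cyclopentyl on an amide-type nitrogen but differs elsewhere, so it offers only a lower reference. A fall somewhat smaller than that large step is expected in this assay. The expected step is a number 0.84 log units lower from compound 1 to compound 4 (beyond the scatter). Compound 4 is estimated at 4.6, with an expected range of 4.2 to 5.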

Compound 4, distribution coefficient: 4.55
The estimate for compound 4 lay 0.05 log units above the measured number; the range from low to high includes it.
By their numbers in this assay, from the lowest: compounds 2, 3 and 4 (each within the scatter of the next, the first and the last beyond it); then compound 1.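

Cyclopentyl in place of cycloheptyl on the amide-type nitrogen now has its own direct step in this assay (a number 0.89 log units lower from compound 1 to compound 4 (beyond the scatter)), while cyclopentylamino and piperidin-1-yl on the carbonyl carbon are not separated (a number 0.28 log units higher from compound 3 to compound 4 (within the scatter)). With cyclopentylamino held fixed, the far end of the chain also registers, with 4-methylpiperazin-1-yl in place of pyrrolidin-1-yl (a number 0.51 log units higher from compound 2 to compound 4 (beyond the scatter)). No evidence on hand accounts for these steps. Still open, from the compounds shown here alone, is where cyclohexyl on this nitrogen would fall, and whether an open-chain group such as tert-butyl would follow the cyclopentyl result.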